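The compounds below may be only part of what the source reports. "The series", "measured", "known", "first", "only" and "open" are said of these compounds alone.

In a functional assay on the whole organism with Rattus norvegicus as the target (a higher number here means that more compound is needed for the effect, a lower number that less compound is needed), compound 1 (`CCOC(=O)C(=O)Nc1cccc(N)c1C#N`) gives 0.07 mg/kg and compound 2 (`CCOC(=O)C(=O)Nc1cccc(NC)c1C#N`) gives 0.1 mg/kg on the shared core. Going by the values given here, compound 2 therefore cannot be separated from compound 1, the only other measured compound. Compound 3 (`CCCCNc1cccc(NC(=O)C(=O)OCC)c1C#N`) differs from compound 2 by propyl in place of hydrogen on a saturated chain carbon bound to a nitrogen on an aromatic ring in one place: propyl in place of hydrogen on a saturated chain carbon bound to a nitrogen on an aromatic ring, so that methylamino becomes butylamino. Among the compounds with values here, only one measured step bears on this: a 1.4-fold higher number from compound 1 to compound 2 (0.15 log units; within the scatter) for methyl in place of hydrogen on a nitrogen on an aromatic ring. No longer chain has been measured, so the expectation is weakly supported: a small rise in the number, of about that size and probably within the scatter. For compound 3 the estimated value is 0.15 mg/kg (expected range 0.05 mg/kg to 0.5 mg/kg). This estimate means an expected 1.5-fold higher number from compound 2 to compound 3 (0.18 log units; within the scatter) in this assay as the working figure.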

Compound 3, dose for half-maximal effect: 0.3 mg/kg
Compound 3: the middle estimate sits 2.0-fold (0.30 log units) below what was measured, and the stated range covers the measured number.
By their numbers in this assay, from the lowest: compounds 1 and 2 (each within the scatter of the next); then compound 3.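

In this assay, going by these compounds alone, the change from methylamino to butylamino gives a 3.0-fold higher number from compound 2 to compound 3 (0.48 log units; beyond the scatter) and is the first step to lie beyond the scatter, whereas methyl in place of hydrogen on a nitrogen on an aromatic ring gave only a 1.4-fold higher number from compound 1 to compound 2 (0.15 log units; within the scatter) in the earlier step. Taken from the primary amine, butyl in place of hydrogen on that nitrogen gives a 4.3-fold higher number from compound 1 to compound 3 (0.63 log units; beyond the scatter) as the full change, so among these three compounds the number separates only once the group is longer than methyl. No available evidence explains this rise.

As far as these compounds go, whether the number keeps rising with a longer chain such as hexyl, or with a branched group such as isobutyl, remains open. Also open, from the compounds shown here alone, is how an acetyl or 2-hydroxyethyl group on this nitrogen would compare with butyl.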